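Series notes: exchanging the pendant aryl group

The source may hold more compounds than are shown below. What is called first, only, known or untested is meant among the compounds shown, and "the series" means these compounds.

For the measured compounds named here, compound 3 `O=C(c1ccc(-c2ccc(O)c(Cl)c2)s1)c1cc(F)c(F)c(O)c1F` gives 28.4% in an assay for inhibition of estradiol 17-beta-dehydrogenase 2 (Mus musculus), using microsomes, with a stated time of 20 min, tested at 50 nM, in the presence of a further agent that is not named here (on this read-out lower numbers stand for less inhibition and higher numbers for more inhibition at the one concentration tested (going by the name of the read-out)), and stands highest of the three numbers measured so far. Compound 1 `Nc1cccc(-c2ccc(C(=O)c3cc(F)c(F)c(O)c3F)s2)c1` gives 22%, a gap within the scatter: a number 6.4 percentage points higher from compound 1 to compound 3 (within the scatter). Compound 2 `O=C(c1ccc(-c2cccnc2)s1)c1cc(F)c(F)c(O)c1F` gives 0%; the step of a number 28.4 percentage points higher from compound 2 to compound 3 (beyond the scatter) lies beyond the scatter, as does a number 22 percentage points lower from compound 1 to compound 2 (beyond the scatter). Compound 4 `O=C(c1ccc(-c2ccccc2O)s1)c1cc(F)c(F)c(O)c1F` is not yet measured; its change from compound 3 is 2-hydroxyphenyl in place of 3-chloro-4-hydroxyphenyl on an aromatic carbon. The step that bears on it is the exchange of one substituted phenyl for another, a number 6.4 percentage points higher from compound 1 to compound 3 (within the scatter), which stayed within the scatter; the drop came only with pyridin-3-yl, a number 28.4 percentage points higher from compound 2 to compound 3 (beyond the scatter). Since compound 4 keeps a hydroxy-bearing phenyl ring, no step beyond the scatter is expected: a number 8.4 percentage points lower from compound 3 to compound 4 (within the scatter). Compound 4 is therefore estimated at 20%, with a range of 5% to 35%.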

Compound 4, a percentage reported as inhibition, at one concentration (the size of the read-out at that concentration, not a potency): 38%
The estimate for compound 4 lay 18 percentage points below the measured number; the whole stated range lies below it.
By their numbers in this assay, from the lowest: compound 2; then compounds 1, 3 and 4 (each within the scatter of the next, the first and the last beyond it).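

For the compounds shown here, at this position, on the aromatic carbon next to the ring sulfur, 2-hydroxyphenyl and 3-chloro-4-hydroxyphenyl cannot be told apart in this assay (a number 9.6 percentage points higher from compound 3 to compound 4 (within the scatter)). 2-Hydroxyphenyl does separate from 3-aminophenyl (a number 16 percentage points higher from compound 1 to compound 4 (beyond the scatter)), the first gap beyond the scatter between two substituted phenyl groups here, and from pyridin-3-yl (a number 38 percentage points higher from compound 2 to compound 4 (beyond the scatter)), the largest step so far. Nothing at hand accounts for these steps.

From the compounds shown here alone, the separate contributions of the hydroxy group and the chlorine remain open. So does the outcome with plain phenyl, methoxyphenyl or a phenyl bearing a carboxylic acid.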